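A few compounds are considered here, and "the series" means these few. Any claim that something is new, unique, unknown or untested is made for them only; others in the source may bear on it.

Measured so far in an ADME assay (liver) for metabolic stability, with Liver microsome (Rattus norvegicus) as the target, using microsomes and NADPH, with a stated time of 30 min, tested at 1 uM; a higher number here means faster removal of the compound, a lower number slower removal:
compound 1 `CC(C)n1cc(-c2cc(C(O)(C(F)(F)F)C(F)(F)F)cnc2N2CCN(S(=O)(=O)c3ccc(N)nc3)CC2)cn1`: 198 mL.min-1.g-1
compound 2 `Nc1ccc(S(=O)(=O)N2CCN(c3ncc(C(O)(C(F)(F)F)C(F)(F)F)cc3-c3ccncc3)CC2)cn1`: 31 mL.min-1.g-1

In this assay compound 2 stands at 31 mL.min-1.g-1, the lower of the two numbers. Next comes compound 3 `Nc1ccc(S(=O)(=O)N2CCN(c3ncc(C(O)(C(F)(F)F)C(F)(F)F)cc3-c3cccnc3)CC2)cn1`, with pyridin-3-yl in place of pyridin-4-yl on an aromatic carbon. Among the measured compounds shown here, one measured step bears on this, a 6.4-fold lower number from compound 1 to compound 2 (0.81 log units; beyond the scatter), where pyridin-4-yl replaced 1-isopropyl-1H-pyrazol-4-yl at the same place. That step changed the ring type and removed the isopropyl group, whereas the new change only moves the ring nitrogen. For the measured compounds named here, no pair tests such a move, so the earlier step sets no size for it. A small rise at most is expected, not beyond the scatter. The expected step is a 1.3-fold higher number from compound 2 to compound 3 (0.11 log units; within the scatter). The estimate for compound 3 is 40 mL.min-1.g-1, with an expected range of 17 mL.min-1.g-1 to 100 mL.min-1.g-1.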

Compound 3, intrinsic clearance in microsomes: 20 mL.min-1.g-1
The estimate for compound 3 lay 2.0-fold (0.30 log units) above the measured number; measured number inside the range.
By their numbers in this assay, from the lowest: compounds 3 and 2 (each within the scatter of the next); then compound 1.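

In this assay, moving the ring nitrogen at this place, ortho to a large group, gives a 1.6-fold lower number from compound 2 to compound 3 (0.19 log units; within the scatter), so the compounds shown do not separate pyridin-3-yl from pyridin-4-yl here. Replacing 1-isopropyl-1H-pyrazol-4-yl with pyridin-3-yl gives a 9.9-fold lower number from compound 1 to compound 3 (1.00 log units; beyond the scatter), so the gap from compound 1 now holds for both pyridine isomers and does not depend on one nitrogen position. No measurement at hand gives a reason for either step.

Still open, on these data alone, is whether the gap from compound 1 goes with the ring type or with the isopropyl group, as both change together in each step. Also open, as far as these compounds go, is how a plain phenyl ring or an unsubstituted pyrazol-4-yl group at this place would compare.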